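A few compounds are considered here, and "the series" means these few. Any claim that something is new, unique, unknown or untested is made for them only; others in the source may bear on it.

Compound 2 `O=C1c2c[n+]([O-])c3ccccc3c2C(=O)c2c1c1ccccc1n2CCCCN1CCCCC1` gives 610 nM in a functional assay on MDA-MB-231 cells (Homo sapiens) for cytotoxicity, read by MTT assay, with a stated time of 72 h (a lower number here means a stronger inhibitor, a higher number a weaker inhibitor), which places it second highest of the three numbers measured: compound 1 `CC1(C)OCC(Cn2cc(Cn3c4c(c5ccccc53)C(=O)c3c[n+]([O-])c5ccccc5c3C4=O)nn2)O1` gives 230 nM, and compound 3 `CCCN1CCN(CCCCn2c3c(c4ccccc42)C(=O)c2c[n+]([O-])c4ccccc4c2C3=O)CC1` gives 2980 nM. Within the data shown here, the one step that can be read directly is a 4.9-fold higher number from compound 2 to compound 3 (0.69 log units; beyond the scatter), a change at the far end of the saturated chain. The move to compound 4 `O=C1c2c[n+]([O-])c3ccccc3c2C(=O)c2c1c1ccccc1n2Cc1cn(C[C@H](O)CO)nn1` is a different and larger change: 1-(2,3-dihydroxypropyl)-1H-1,2,3-triazol-4-yl in place of 3-(piperidin-1-yl)propyl on a saturated chain carbon bound to an aromatic nitrogen. Among the measured compounds shown here, no measured step covers this exchange. What bears on it is that compound 1 carries a closely related triazolyl group on the same kind of chain carbon, and its number sits a little below that of compound 2, with the gap beyond the scatter but still modest. Compound 4 is therefore expected to land near compound 1 rather than near compound 3, with a step of a 1.7-fold lower number from compound 2 to compound 4 (0.24 log units; within the scatter) from compound 2. The estimate for compound 4 is 350 nM, within a range from 120 nM to 1000 nM.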

Compound 4, half-maximal inhibitory concentration: 1310 nM
The estimate for compound 4 lay 3.7-fold (0.57 log units) below the measured number; measured number outside the range, above it.
By their numbers in this assay, from the lowest: compound 1; then compound 2; then compound 4; then compound 3.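

In this assay the triazole linkage alone does not secure a low number, since 1,2-dihydroxyethyl in place of 2,2-dimethyl-1,3-dioxolan-4-yl on the saturated chain carbon gives a 5.7-fold higher number from compound 1 to compound 4 (0.76 log units; beyond the scatter) and the outer end of the triazolyl group therefore counts. Set against the amine chains, the triazolyl group with its diol gives a 2.1-fold higher number from compound 2 to compound 4 (0.33 log units; beyond the scatter) for the 3-(piperidin-1-yl)propyl exchange and a 2.3-fold lower number from compound 3 to compound 4 (0.36 log units; beyond the scatter) for the 3-(4-propylpiperazin-1-yl)propyl exchange, so neither kind of group ranks consistently above the other: compound 1 has a lower number than compound 2, while compound 4 has a higher one. Nothing available explains these differences.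

From the compounds shown here alone, it remains open how the opposite configuration at the stereocentre of compound 4, a single hydroxyl or a methyl ether on the triazolyl side chain would compare. Going by these compounds, a morpholine in place of the piperidine of compound 2 is equally open.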